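Sulfonamide nitrogen methylation in the aorta series

This account rests on a few compounds, and the source may have more. Where it says the series, first, only, none or still open, it means among the compounds named here.

Compound 2 `CCCCc1ccc(CNS(=O)(=O)c2ccc(C)cc2)c(=O)n1Cc1ccc(-c2ccccc2-c2nn[nH]n2)cc1` is measured in a functional assay (aorta) for antagonist activity, with Oryctolagus cuniculus as the target (on this read-out higher numbers stand for weaker inhibition and lower numbers for stronger inhibition), and gives 9 nM. Compound 1 `CCCCNC(=O)NCc1ccc(CCCC)n(Cc2ccc(-c3ccccc3-c3nn[nH]n3)cc2)c1=O` gives 10 nM in this assay, and the only measured step, a 1.1-fold lower number from compound 1 to compound 2 (0.05 log units; within the scatter), lies within the scatter, so compound 2 and compound 1 are indistinguishable on the numbers shown; compound 2 carries the lower of the two numbers without that meaning anything beyond noise.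

Compound 3 `CCCCc1ccc(CN(C)S(=O)(=O)c2ccc(C)cc2)c(=O)n1Cc1ccc(-c2ccccc2-c2nn[nH]n2)cc1` is not yet measured. It differs from compound 2 by methyl in place of hydrogen on a sulfonamide nitrogen. Going by the values given here, no measured step touches the sulfonamide nitrogen: the step from compound 1 to compound 2 exchanged the whole substituent on an amine nitrogen, not a hydrogen for methyl on it, so it gives no direct guide. With nothing to support a shift either way, the expectation for compound 3 in this assay is a step of about a 1.3-fold higher number from compound 2 to compound 3 (0.12 log units; within the scatter), not beyond the scatter. Compound 3 is estimated at 12 nM, with a range from 4 nM to 40 nM.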

Compound 3, half-maximal inhibitory concentration: 8 nM
Estimate against measurement, compound 3: 1.5-fold (0.18 log units) above, and the stated range covers the measured number.
By their numbers in this assay, from the lowest: compounds 3, 2 and 1 (each within the scatter of the next).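

In this assay the sulfonamide nitrogen accepts methyl in place of its hydrogen, with a 1.1-fold lower number from compound 2 to compound 3 (0.05 log units; within the scatter), so on these numbers a hydrogen on this nitrogen is not required for the read-out. The earlier step exchanged a whole substituent on the amine nitrogen, whereas this one isolates the sulfonamide hydrogen, and a 1.3-fold lower number from compound 1 to compound 3 (0.10 log units; within the scatter) shows that methyl((4-methylphenyl)sulfonyl)amino and (butylcarbamoyl)amino also cannot be told apart. No measurement at hand explains why this position accepts the change.

Still open, as far as these compounds go, is whether a group larger than methyl on this nitrogen, such as ethyl, a longer chain or carboxymethyl, stays equally close to compound 2. Also open, from the compounds shown here alone, is whether the methyl step reads the same when (4-methylphenyl)sulfonyl gives way to methylsulfonyl.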